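The compounds below may be only part of what the source reports. "The series", "measured", "known", "first", "only" and "open" are said of these compounds alone.

Compound 1, `CCN(CC)S(=O)(=O)c1ccc(S(=O)(=O)N2CCC[C@@H](C(=O)N3CCC(F)(F)CC3)C2)cc1`, gives 16 nM in a functional assay on MIA PaCa-2 cells (Homo sapiens) for inhibition, read by MTT assay, with a stated time of 7 days; on this read-out higher numbers stand for weaker inhibition and lower numbers for stronger inhibition.
Compound 2, `O=C([C@@H]1CCCN(S(=O)(=O)c2ccc(S(=O)(=O)C3CCC3)cc2)C1)N1CCC(F)(F)CC1`, gives 9 nM in this assay.
Compound 3, `CCN(CC)S(=O)(=O)c1ccc(S(=O)(=O)N2CCC[C@@H](C(=O)N3CCS(=O)(=O)CC3)C2)cc1`, gives 900 nM in this assay.

Compound 3 stands highest of the three numbers. Within the data shown here, compound 1 is nearest to it, with a 56-fold higher number from compound 1 to compound 3 (1.75 log units; beyond the scatter), while compound 2 is furthest, and no single-change step links compound 2 to compound 3. Compound 4, `CCN(CC)S(=O)(=O)c1ccc(S(=O)(=O)N2CCC[C@@H](C(=O)N3CCC(O)CC3)C2)cc1`, is the next compound to be measured; it differs from compound 3 in one place: 4-hydroxypiperidin-1-yl in place of 1,1-dioxothiomorpholin-4-yl on a carbonyl carbon. Of the two measured steps, the one that bears on this position is a 56-fold higher number from compound 1 to compound 3 (1.75 log units; beyond the scatter), which shows that the group on the carbonyl carbon can move the number a long way; the other, a 1.8-fold lower number from compound 1 to compound 2 (0.25 log units; within the scatter), concerns the sulfonyl sulfur and says nothing about this position. Compound 4 carries at this place neither the group of compound 1 nor that of compound 3, so the data give no direct anchor for it. A step in this assay back toward the lower numbers is expected, of moderate size: a 6.0-fold lower number from compound 3 to compound 4 (0.78 log units; beyond the scatter). Compound 4 is therefore estimated at 150 nM, within 30 nM to 700 nM.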

Compound 4, half-maximal inhibitory concentration: 870 nM
Compound 4: middle estimate off by 5.8-fold (0.76 log units), on the low side; the measured number lies above the stated range.
By their numbers in this assay, from the lowest: compounds 2 and 1 (each within the scatter of the next); then compounds 4 and 3 (each within the scatter of the next).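

In this assay, the step to 4-hydroxypiperidin-1-yl on the carbonyl carbon is a 1.0-fold lower number from compound 3 to compound 4 (0.01 log units; within the scatter), so this assay does not separate this group from 1,1-dioxothiomorpholin-4-yl, even though the two rings differ in their hetero atoms and only the entering group carries a hydrogen-bond donor. Measured against the 4,4-difluoropiperidin-1-yl group, the same replacement gives a 54-fold higher number from compound 1 to compound 4 (1.74 log units; beyond the scatter), which shows that the large rise seen with compound 3 is not confined to the 1,1-dioxothiomorpholin-4-yl group: of the three groups shown at this position, only 4,4-difluoropiperidin-1-yl goes with the low numbers. Nothing shown accounts for the close agreement of compound 3 and compound 4 or for their distance from compound 1.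

The compounds shown leave open where a plain piperidin-1-yl, a 4-fluoropiperidin-1-yl or a 4-methoxypiperidin-1-yl group would stand on the carbonyl carbon, and so whether the low numbers follow the fluorines or the piperidine ring without a hydroxyl group. They also leave open whether cyclobutyl on the sulfonyl sulfur would still match diethylamino when paired with 4-hydroxypiperidin-1-yl.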